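The source may hold more compounds than are shown below. What is called first, only, known or untested is meant among the compounds shown, and "the series" means these compounds.

- compound 1 `COc1ccc(N(C)c2ncnc3c2ncn3Cc2cc(OC)c(OC)c(OC)c2)cc1`: 260 nM
- compound 2 `COc1ccc(N(C)c2nc(Cl)nc3c2ncn3Cc2cc(OC)cc(OC)c2)cc1`: > 100000 nM (a limit)

In a functional assay on SH-SY5Y cells (Homo sapiens) for antiproliferative activity, read by MTT assay, with a stated time of 48 h (on this read-out lower numbers stand for stronger inhibition of growth and higher numbers for weaker inhibition of growth), compound 1 gives 260 nM. Compound 2 stands at > 100000 nM, which is a limit of the assay and not a number. Compound 3 `COc1ccc(N(C)c2nc(Cl)nc3c2ncn3Cc2cc(OC)c(OC)c(OC)c2)cc1` differs from compound 2 by a single change, (methoxy in place of hydrogen on an aromatic carbon). Among the compounds with values here, no measured step shows this change, so its size is a judgement. Within the data shown here, the only numerical value available is that of compound 1, at 260 nM, and a large gain in growth inhibition towards that level is expected. The estimated step is an at least 160-fold lower number from compound 2 to compound 3 (2.22 log units; beyond the scatter). For compound 3 the estimate is 600 nM, with an expected range of 40 nM to 15000 nM.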

Compound 3, concentration for 50% growth inhibition: 3000 nM
For compound 3 the middle estimate is 5.0-fold (0.70 log units) below the measured one; low and high end bracket the measured number.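

In this assay, methoxy in place of hydrogen on the aromatic carbon ortho to two methoxy groups gives an at least 33-fold lower number from compound 2 to compound 3 (1.52 log units; beyond the scatter), so this position clearly matters for growth inhibition. Compound 2 stands at > 100000 nM, a limit and not a number, so that step is only a bound: the limit of > 100000 nM in this assay, at which 1 of the 3 values shown sits.

The chloro change gives a 12-fold higher number from compound 1 to compound 3 (1.06 log units; beyond the scatter), a clear loss that still leaves measurable inhibition once the methoxy is present.

From the compounds shown here alone, whether a hydroxyl, an ethoxy or an amine at this carbon would serve as well stays open. So does the size of the methoxy step on a core without the chloro.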